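The source may report more compounds than this note shows. Statements on the series, on what has been measured and on what is new or still open speak of the compounds shown alone.

Compound 1 `COc1ccc2nc(C)cc(OCC(=O)Nc3cc(C)cc(C)c3)c2c1` gives 20000 nM in a toxicity assay on HepG2 cells (Homo sapiens) for inhibition, read by CellTiter-Glo, with a stated time of 48 h; on this read-out lower numbers stand for stronger inhibition and higher numbers for weaker inhibition.
Compound 2 `CSc1ccc2nc(C)cc(OCC(=O)Nc3cc(C)cc(C)c3)c2c1` shows only > 100000 nM in this assay, a limit of the assay rather than a number.
Compound 3 `CCOc1ccc2nc(C)cc(OCC(=O)Nc3cc(C)cc(C)c3)c2c1` likewise stops at > 100000 nM in this assay, again a limit and not a number.

Going by the values given here, compound 1 therefore holds the only number among the three; the other two values are limits. Compound 4 `COc1ccc2nc(C)cc(OCC(=O)Nc3ccc(Cl)c(OC)c3)c2c1` differs from compound 1 at the amide: 4-chloro-3-methoxyphenyl in place of 3,5-dimethylphenyl on an amide-type nitrogen. The measured steps all change the ether group on the shared core, an at least 5.0-fold higher number from compound 1 to compound 2 (0.69 log units; beyond the scatter) and an at least 5.0-fold higher number from compound 1 to compound 3 (0.69 log units; beyond the scatter), while a step that the two limits leave unreadable from compound 2 to compound 3; none touches the amide-type nitrogen, so none bears directly on this change. Given (the limit of > 100000 nM in this assay, at which 2 of the 3 values shown sit), compound 4 is expected to land near compound 1 or weaker. Compound 4 is estimated at 40000 nM (range 10000 nM to 150000 nM), meaning a 2.0-fold higher number from compound 1 to compound 4 (0.30 log units; within the scatter) is expected.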

Compound 4, half-maximal inhibitory concentration: > 100000 nM
Compound 4: a limit, no number; the forecaster's own chance of this, stated with the estimate: 45%; middle value at least 2.5-fold (0.39 log units) from the limit.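

Going by these compounds alone, compound 4 brings the first change at the amide-type nitrogen, and it shows that this place, not only the ether group on the shared core, affects the read-out in this assay: 4-chloro-3-methoxyphenyl in place of 3,5-dimethylphenyl gives an at least 5.0-fold higher number from compound 1 to compound 4 (0.69 log units; beyond the scatter). The value of compound 4 is a limit and not a number, so the full size of this step cannot be read: the limit of > 100000 nM in this assay, at which 3 of the 4 values shown sit.

Going by these compounds, whether the chlorine or the methoxy group carries the step stays open. So does what a phenyl ring bearing an amine or a carboxylic acid would give at this nitrogen.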